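The source may report more compounds than this note shows. Statements on the series, on what has been measured and on what is new or still open speak of the compounds shown alone.

Going by the values given here, the three compounds measured so far share one core and differ only in the group on the saturated chain carbon bound to an aromatic nitrogen. Compound 1 `CNC(=O)c1cc(C(=O)NC2CC2)cn(Cc2cccc(F)c2)c1=O` carries a fluorophenyl group there. In a physicochemical assay for solubility (a higher number here means a more soluble compound, a lower number a less soluble compound), compound 1 reaches a limit of the assay, >= 133 ug/mL. Compound 2 `CNC(=O)c1cc(C(=O)NC2CC2)cn(Cc2nccc3[nH]ccc23)c1=O` carries a bicyclic group in its place, and in this assay compound 2 gives 73 ug/mL. Compound 3 `CNC(=O)c1cc(C(=O)NC2CC2)cn(Cc2cccc(C)c2)c1=O` carries a methylphenyl group. In this assay compound 3 again reaches a limit, >= 205 ug/mL, so its standing is known only as that limit. Among the compounds with values here, of the measured steps, an at least 1.8-fold lower number from compound 1 to compound 2 (0.26 log units; that floor lies within the scatter) and an at least 2.8-fold higher number from compound 2 to compound 3 (0.44 log units; beyond the scatter) concern the exchange of the whole aromatic group, while a step that the two limits leave unreadable from compound 1 to compound 3, the only step that swaps one small substituent for another on the phenyl ring.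

Compound 4 `CNC(=O)c1cc(C(=O)NC2CC2)cn(Cc2cccc(C#N)c2)c1=O` continues that line: cyano in place of methyl on an aromatic carbon. Within the data shown here, no measured step places a cyano group anywhere, and the one step closest in kind, the exchange of fluoro for methyl, gives no readable size. The step of an at least 1.3-fold lower number from compound 3 to compound 4 (0.13 log units; that floor lies within the scatter) is therefore expected to be small and of uncertain direction. Compound 4 is estimated at 150 ug/mL in this assay, with a range from 60 ug/mL to 300 ug/mL.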

Compound 4, solubility: >= 148 ug/mL
Compound 4 ended at the assay's limit; the forecaster's own chance of this, stated with the estimate: 35%; the middle value does not contradict the limit.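

In this assay compound 4 also ends at a limit, >= 148 ug/mL. With the 3-cyanophenyl group, all three compounds shown with a substituted phenyl group on the saturated chain carbon now stand at limits, including one whose new substituent brings a triple bond and a hydrogen-bond acceptor, while compound 2, with the bicyclic group, alone has a plain number. Going by these compounds alone, the one readable new comparison is an at least 2.0-fold higher number from compound 2 to compound 4 (0.30 log units; that floor lies within the scatter), so this pair by itself does not separate the two groups beyond the scatter, and neither the step from compound 1 to compound 4 nor the step from compound 3 to compound 4 can be read, as each joins two limits.

Where compound 1, compound 3 and compound 4 truly stand relative to one another stays open, as their limits set no order among them. Also open, as far as these compounds go, is whether an aminomethyl group or a carboxylic acid on the same aromatic carbon would give a limit or a plain number, and how a phenyl group with no substituent would compare.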